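The source may hold more compounds than are shown below. What is called first, only, known or untested is meant among the compounds shown, and "the series" means these compounds.

Compound 2, `CC(C(=O)N1CCN(c2ccc(F)cc2)CC1)N1C(=O)CCC1=O`, stands second highest of the three compounds measured in a functional assay on the whole organism (strain Swiss) with Mus musculus as the target, in the maximal electroshock model, with a stated time of 1 h, at a dose of 300 mg/kg by the intraperitoneal route (on this read-out higher numbers stand for a stronger effect at the one dose given and lower numbers for a weaker effect), where compound 2 gives 25%. Its nearest neighbour on that scale is compound 3, `CC(C(=O)N1CCN(c2ccc(C(F)(F)F)cc2)CC1)N1C(=O)CCC1=O`, which gives 0%; the furthest is compound 1, `CC(C(=O)N1CCN(c2cccc(Cl)c2)CC1)N1C(=O)CCC1=O`, which gives 75%.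

The step under consideration leads from compound 2 to compound 4, `CC(C(=O)N1CCN(c2ccccc2Cl)CC1)N1C(=O)CCC1=O`, and the change is 2-chlorophenyl in place of 4-fluorophenyl on an amine nitrogen in a ring.

Going by the values given here, two measured steps bear on it. The first, a number 50 percentage points lower from compound 1 to compound 2 (beyond the scatter), is the only one in which a chlorophenyl group is exchanged for a fluorophenyl group on the same ring nitrogen, and it is large. The second, a number 25 percentage points lower from compound 2 to compound 3 (beyond the scatter), is modest and runs in the same direction, but it changes only the group on the aromatic carbon and not the halogen or its name. From the compounds shown here alone, neither step compares a 2-chlorophenyl with anything else, so the halogen exchange is the stronger guide, and the change of the group's position on the ring is unknown territory.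

Compound 4 is therefore expected to move upward, with an estimated step of a number 25 percentage points higher from compound 2 to compound 4 (beyond the scatter). The estimate for compound 4 in this assay is 50%, with a range from 20% to 80%.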

Compound 4, a percentage reported as activity, at one dose (the size of the read-out at that dose, not a potency): 25%
For compound 4 the middle estimate is 25 percentage points above the measured one; measured number inside the range.
By their numbers in this assay, from the lowest: compound 3; then compounds 2 and 4 (each within the scatter of the next); then compound 1.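

Keeping chlorine on the phenyl group and changing only its place, 2-chlorophenyl in place of 3-chlorophenyl, gives a number 50 percentage points lower from compound 1 to compound 4 (beyond the scatter) in this assay, so the presence of a chlorine alone does not carry the level seen for compound 1 75%. Exchanging 4-fluorophenyl for 2-chlorophenyl, which alters both the halogen and its place on the phenyl group, gives no change at the digits printed from compound 2 to compound 4 (within the scatter), so this pair does not separate one halogen from the other on this read-out. Nothing available here explains why the place of the chlorine matters so much in this small set.

The compounds shown leave open whether bromine or a methoxy group in place of the chlorine of the 3-chlorophenyl group would hold the level of compound 1, which would tell whether that place favours chlorine in particular or accepts other groups. They also leave open how a plain phenyl group on the same amine nitrogen would read, and so whether any of these halogens adds to the effect at all.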